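The source may report more compounds than this note shows. Statements on the series, on what has been measured and on what is new or still open speak of the compounds shown alone.

Compound 3 `O=C(NCCO)c1cccc2[nH]c(-c3cccnc3)nc12` gives the highest of the three numbers in an ADME assay on Vero cells (Chlorocebus sabaeus) for cytotoxicity (on this read-out lower numbers stand for higher toxicity in this test and higher numbers for lower toxicity in this test), with a value of 682 uM. Its nearest neighbour is compound 1 `O=C(NCCO)c1cccc2[nH]c(-c3ccccn3)nc12`, which in this assay gives 568 uM; the step of a 1.2-fold higher number from compound 1 to compound 3 (0.08 log units; within the scatter) lies within the scatter. The furthest is compound 2 `O=C(Nc1ccccc1F)c1cccc2[nH]c(-c3ccccn3)nc12`, which gives 54.7 uM in this assay, a number well beyond the scatter below that of compound 3.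

Compound 4 `Cc1csc(NC(=O)c2cccc3[nH]c(-c4cccnc4)nc23)n1` differs from compound 3 in one place: 4-methyl-1,3-thiazol-2-yl in place of 2-hydroxyethyl on an amide-type nitrogen. Going by the values given here, the only measured step that bears on this change is a 10-fold lower number from compound 1 to compound 2 (1.02 log units; beyond the scatter), where an aromatic ring replaced the 2-hydroxyethyl group on the same amide-type nitrogen. Among the compounds with values here, no step with the pyridin-3-yl core of compound 3 and an aromatic amide is known; the step of a 1.2-fold higher number from compound 1 to compound 3 (0.08 log units; within the scatter) shows that the pyridin-2-yl to pyridin-3-yl change did little on its own, so the amide change is expected to carry the effect. Because a 10-fold lower number from compound 1 to compound 2 (1.02 log units; beyond the scatter) was large, a step of comparable size in the same direction is expected here, and compound 4 is estimated to show a 9.7-fold lower number from compound 3 to compound 4 (0.99 log units; beyond the scatter) in this assay. Compound 4 is therefore expected to give about 70 uM, with a likely range from 25 uM to 200 uM.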

Compound 4, half-maximal toxic concentration: 111 uM
Beside the measured number, compound 4's estimate is 1.6-fold (0.20 log units) below it; the range from low to high includes it.
By their numbers in this assay, from the lowest: compound 2; then compound 4; then compounds 1 and 3 (each within the scatter of the next).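

In this assay, 4-methyl-1,3-thiazol-2-yl in place of 2-hydroxyethyl on the amide-type nitrogen gives a 6.1-fold lower number from compound 3 to compound 4 (0.79 log units; beyond the scatter), so a lower number at this position now appears with the pyridin-3-yl group as well as with the pyridin-2-yl group, for which the earlier step was a 10-fold lower number from compound 1 to compound 2 (1.02 log units; beyond the scatter). The fall is also not tied to 2-fluorophenyl: a five-membered aromatic ring with 2 hetero atoms moves the number in the same direction, and in both pairs the compound carrying 2-hydroxyethyl has the higher number. No measurement shown here gives a reason for this fall.

The compounds shown leave open whether the lower number comes with the aromatic ring itself or with the loss of 2-hydroxyethyl, a question that a longer chain such as 3-hydroxypropyl, an amine such as 2-aminoethyl, or a plain cyclohexyl ring on the same nitrogen could address. They also leave open how the methyl group on the thiazole contributes, since the unsubstituted 1,3-thiazol-2-yl amide does not appear among them.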